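Swapping a chloro for a hydroxy on a weak binder

This account rests on a few compounds, and the source may have more. Where it says the series, first, only, none or still open, it means among the compounds named here.

Compound 1 `COc1ccc(COc2ccccc2-c2cc(CO)on2)cc1` is measured in an assay with Cystic fibrosis transmembrane conductance regulator (Rattus norvegicus) as the target (a higher number here means weaker binding, a lower number tighter binding), and gives 64000 nM, a value that marks only weak binding. Compound 2 `COc1ccc(COc2ccc(Br)cc2-c2cc(CCl)on2)cc1` differs from it in two places: a bromo sits on the ring that carries the ether, and the hydroxymethyl has become a chloromethyl. For compound 2 this assay returns only a limit, > 300000 nM, so its true binding is not pinned to a number. Within the data shown here, that limit is the limit of > 300000 nM in this assay, at which 1 of the 2 values shown sits, and it says only that compound 2 binds no tighter than the assay can still resolve. Compound 3 `COc1ccc(COc2ccc(Br)cc2-c2cc(CO)on2)cc1` keeps the bromo of compound 2 but carries hydroxy in place of chloro on a saturated chain carbon bound to an aromatic carbon. Among the measured compounds shown here, no measured pair shows this exact exchange, so the size of the step is uncertain; compound 1 with its hydroxymethyl does give a number where compound 2 gives none, which points toward tighter binding for compound 3 than for compound 2. Compound 3 is therefore expected to bind near 110000 nM, with a range from 35000 nM to 350000 nM, which means an expected step of an at least 2.7-fold lower number from compound 2 to compound 3 (0.43 log units; beyond the scatter) from the limit toward a measurable value.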

Compound 3, dissociation constant: 104000 nM
For compound 3 the middle estimate is 1.1-fold (0.02 log units) above the measured one; the range from low to high includes it.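

In this assay, with the bromo held in place, the exchange of chloromethyl for hydroxymethyl can now be read on its own, and it gives an at least 2.8-fold lower number from compound 2 to compound 3 (0.46 log units; beyond the scatter), so on this chain carbon the hydroxy yields a measurable value where the chloro yields none. That step is only a minimum, since compound 2 gives a limit of the assay and not a number: the limit of > 300000 nM in this assay, at which 1 of the 3 values shown sits.

The bromo, which was tied up with the chloro in the earlier comparison, can also be read alone now: with hydroxymethyl present in both compounds, bromo in place of hydrogen on an aromatic carbon gives a 1.6-fold higher number from compound 1 to compound 3 (0.21 log units; within the scatter), a difference that stays within the scatter, so in this assay the bromo cannot be told apart from hydrogen.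

The compounds shown leave open whether an amine or a carboxylic acid on this chain carbon, or a longer chain ending in a hydroxy, would bind tighter than the hydroxymethyl does. They also leave open whether the step from chloromethyl to hydroxymethyl has the same size on the core of compound 1, without the bromo.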